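A few compounds are considered here, and "the series" means these few. Any claim that something is new, unique, unknown or untested is made for them only; others in the source may bear on it.

Measured in an ADME assay on BaF3 cells (Mus musculus) for cytotoxicity, read by CellTiter-Glo and CCK-8 assay, with a stated time of 72 h; on this read-out higher numbers stand for weaker inhibition of growth and lower numbers for stronger inhibition of growth:
- Compound 1 `CCC(=O)NCc1ccc(C(=O)Nc2ccc(C)c(Nc3nccc(-c4cccnc4)n3)c2)cc1`: > 10000 nM, a limit of the assay
- Compound 2 `C=CC(=O)NCc1ccc(C(=O)Nc2ccc(C)c(Nc3nccc(-c4cccnc4)n3)c2)cc1`: > 10000 nM, a limit of the assay
- Compound 3 `C=CC(=O)Nc1ccc(C(=O)Nc2ccc(C)c(Nc3nccc(-c4cccnc4)n3)c2)cc1`: 5600 nM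

Within the data shown here, compound 3 carries the only true number in this small set. The other two readings stand at the limit of > 10000 nM in this assay, at which 2 of the 3 values shown sit.

Compound 4 `Cc1ccc(NC(=O)c2ccc(CNCCN(C)C)cc2)cc1Nc1nccc(-c2cccnc2)n1` is still unmeasured, and it changes the same site of compound 3: ((2-(dimethylamino)ethyl)amino)methyl in place of (vinylcarbonyl)amino on an aromatic carbon. Two measured steps involve this site, an at least 1.7-fold lower number from compound 1 to compound 3 (0.25 log units; that floor lies within the scatter) and an at least 1.7-fold lower number from compound 2 to compound 3 (0.25 log units; that floor lies within the scatter). Neither of them tests the new chain. Going by an at least 1.7-fold lower number from compound 2 to compound 3 (0.25 log units; that floor lies within the scatter), the expectation is no shift beyond the scatter, and the estimated step is a 1.3-fold higher number from compound 3 to compound 4 (0.10 log units; within the scatter). A result reported only as a limit would also fit this expectation.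

For compound 4 the estimated value is 7000 nM, with an expected range from 2500 nM to 20000 nM.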

Compound 4, concentration for 50% growth inhibition: > 10000 nM
Compound 4 ended at the assay's limit (the forecaster's own chance of this, stated with the estimate: 40%); middle value at least 1.4-fold (0.15 log units) away from the limit.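

With ((2-(dimethylamino)ethyl)amino)methyl on this aromatic carbon, the number does not fall, and the readable change is an at least 1.7-fold higher number from compound 3 to compound 4 (0.25 log units; that floor lies within the scatter). Among these compounds, compound 4 is the only compound here that has an amine chain without a carbonyl at this position, and its result is also a limit, like most in the set: the limit of > 10000 nM in this assay, at which 3 of the 4 values shown sit. The steps from compound 1 and compound 2 to compound 4 cannot be read.

The compounds shown leave open whether the vinyl group matters in compound 3. An acetylamino group on the same aromatic carbon would address that question.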